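From 2-Fluorobenzyl to 3-Bromobenzyl on a Shared Core

The compounds below may be only part of what the source reports. "The series", "measured", "known", "first", "only" and "open" are said of these compounds alone.

In a functional assay on HepG2 cells (Homo sapiens) for antiproliferative activity, read by MTT assay, with a stated time of 24 h (on this read-out lower numbers stand for stronger inhibition and higher numbers for weaker inhibition), compound 1 (`O=[N+]([O-])c1cccc(CSc2nnc(-c3ccc4c(c3)OCCO4)n2-c2ccccc2)c1`) gives 49300 nM and compound 2 (`Clc1cccc(CSc2nnc(-c3ccc4c(c3)OCCO4)n2-c2ccccc2)c1`) gives 2390 nM while compound 3 (`Fc1ccccc1CSc1nnc(-c2ccc3c(c2)OCCO3)n1-c1ccccc1`) gives 810 nM and holds the lowest number of the three. On these numbers compound 2 is its nearest neighbour and compound 1 its furthest. Compound 4 (`Brc1cccc(CSc2nnc(-c3ccc4c(c3)OCCO4)n2-c2ccccc2)c1`) has not yet been measured. The change from compound 3 is 3-bromophenyl in place of 2-fluorophenyl on a saturated chain carbon bound to a sulfur with 3-bromophenyl in place of 2-fluorophenyl on a saturated chain carbon bound to a sulfur. Two large steps start from the nitro compound: a 21-fold lower number from compound 1 to compound 2 (1.31 log units; beyond the scatter) and a 61-fold lower number from compound 1 to compound 3 (1.78 log units; beyond the scatter) show how far compound 1 lies from both halogen-bearing compounds, but they say little about an exchange of one halogen for another. The modest step of a 3.0-fold lower number from compound 2 to compound 3 (0.47 log units; beyond the scatter) bears most directly on the question, as compound 2 carries 3-chlorophenyl where compound 4 carries 3-bromophenyl. A step of similar modest size in the opposite direction is therefore expected, towards a higher number. The expected change is estimated as a 3.1-fold higher number from compound 3 to compound 4 (0.49 log units; beyond the scatter) in this assay and would leave the new number near that of compound 2. The estimate for compound 4 is 2500 nM with an expected range (800 nM to 8000 nM).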

Compound 4, half-maximal inhibitory concentration: 5210 nM
Compound 4: the middle estimate sits 2.1-fold (0.32 log units) below what was measured, and the stated range covers the measured number.
By their numbers in this assay, from the lowest: compound 3; then compound 2; then compound 4; then compound 1.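

In this assay the change of chloro to bromo on an aromatic carbon gives a 2.2-fold higher number from compound 2 to compound 4 (0.34 log units; beyond the scatter) and so shows that the identity of the halogen counts at this site, even with 3-chlorophenyl and 3-bromophenyl otherwise alike. The earlier step between compound 2 and compound 3 could not show this, as 3-chlorophenyl and 2-fluorophenyl differ in both halogen and name position. The replacement of 2-fluorophenyl on the saturated chain carbon bound to a sulfur now spans a 6.4-fold higher number from compound 3 to compound 4 (0.81 log units; beyond the scatter) and is larger than the step to the chloro compound, while bromo in place of nitro gives a 9.5-fold lower number from compound 1 to compound 4 (0.98 log units; beyond the scatter) and leaves all three halogen-bearing compounds with lower numbers than the nitro compound.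

No measurement shown here accounts for the order of these four compounds. Going by these compounds, it remains open whether the low number of compound 3 belongs to fluorine or to its placement, which a 3-fluorophenyl or a 2-bromophenyl group would separate, and how an amine or a carboxylic acid on the same ring would compare.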